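The source may report more compounds than this note shows. Statements on the series, on what has been measured and on what is new or still open speak of the compounds shown alone.

The series holds compound 1 `CN1CCN(C(=O)/C=C/c2ccncc2-c2ccc3ccccc3c2)CC1` and compound 2 `COC(=O)/C=C/c1ccncc1-c1ccc2ccccc2c1`. In an assay on a protein complex for inhibition of CDK8/Cyclin C (Homo sapiens), with a stated time of 1 h, tested at 10 uM (on this read-out lower numbers stand for less inhibition and higher numbers for more inhibition at the one concentration tested (going by the name of the read-out)), compound 1 gives 101%, and compound 2 gives 102%. For the measured compounds named here, compound 2 stands highest of the two numbers, but its nearest neighbour compound 1 lies within the scatter of it; the one measured step, a number 1 percentage points higher from compound 1 to compound 2 (within the scatter), is within the scatter, so the two cannot be ordered. Compound 3 `O=C(O)CCNC(=O)/C=C/c1ccncc1-c1ccc2ccccc2c1` is not yet measured. It differs from compound 2 on the carbonyl carbon: (2-carboxyethyl)amino in place of methoxy on a carbonyl carbon. Going by the values given here, the only step bearing on that place, a number 1 percentage points higher from compound 1 to compound 2 (within the scatter), shows that exchanging the group on the carbonyl carbon left the read-out level within the scatter, the two numbers lying close to each other at the one concentration. Among the compounds with values here, the (2-carboxyethyl)amino group itself has no measured precedent here, so the expected step of a number 7 percentage points lower from compound 2 to compound 3 (within the scatter) is taken as none beyond the scatter, with some allowance for the untested group. Compound 3 is accordingly expected to give 95%, within 75% to 104%.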

Compound 3, a percentage reported as inhibition, at one concentration (the size of the read-out at that concentration, not a potency): 91%
Beside the measured number, compound 3's estimate is 4 percentage points above it, and the stated range covers the measured number.
By their numbers in this assay, from the lowest: compounds 3, 1 and 2 (each within the scatter of the next, the first and the last beyond it).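

In this assay, for the compounds shown here, the group on the carbonyl carbon now shows a readable, if modest, difference: (2-carboxyethyl)amino in place of methoxy gives a number 11 percentage points lower from compound 2 to compound 3 (beyond the scatter), the first step beyond the scatter. Against 4-methylpiperazin-1-yl, the same group gives a number 10 percentage points lower from compound 1 to compound 3 (within the scatter), so the difference is readable against only one of the two earlier compounds, and inhibition remains high at the one concentration tested. No measured information here accounts for the step.

Open, on these data alone, is how a free carboxylic acid, a simple amine or a longer chain ending in a carboxylic acid would read on the same carbonyl carbon. With one concentration only and all numbers high, the compounds shown also leave potency differences within the series unresolved.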